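Series notes: chloro for hydrogen on the ring of compound 3

The source may report more compounds than this note shows. Statements on the series, on what has been measured and on what is new or still open speak of the compounds shown alone.

compound 1, `Cc1ccccc1/C=N/NC(=N)NO`: in a functional assay on HL-60 cells (Homo sapiens) for antiproliferative activity (a lower number here means a stronger inhibitor, a higher number a weaker inhibitor), compound 1 gives a limit of > 100000 nM.
compound 2, `N=C(NO)N/N=C/c1ccc(O)cc1`: in this assay compound 2 gives a limit of > 100000 nM.
compound 3, `N=C(NO)N/N=C/c1ccccc1`: in this assay compound 3 gives 62000 nM.

For the measured compounds named here, compound 3 is the only member of the set with a number; the other two values are limits, as two of the three measurements sit at the limit of > 100000 nM in this assay, at which 2 of the 3 values shown sit. Going by the values given here, the step of an at least 1.6-fold lower number from compound 1 to compound 3 (0.20 log units; that floor lies within the scatter) and the step of an at least 1.6-fold lower number from compound 2 to compound 3 (0.20 log units; that floor lies within the scatter) each run from a limit to a number, and each floor lies within the scatter, so they show only that the unsubstituted ring of compound 3 is not weaker than either substituted ring.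

Compound 4, `N=C(NO)N/N=C/c1ccccc1Cl`, is not yet measured. It differs from compound 3 by chloro in place of hydrogen on an aromatic carbon. Among the compounds with values here, no measured step introduces chloro, so the two steps toward compound 3 are the only ones that bear on it; both remove a ring substituent and both lower the number, so adding a substituent back is expected to run the other way, toward a higher number, with a real chance of a limit. In this assay compound 4 is therefore estimated at 100000 nM, between 40000 nM and 250000 nM. The expected step is a 1.6-fold higher number from compound 3 to compound 4 (0.21 log units; within the scatter), within the scatter.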

Compound 4, half-maximal inhibitory concentration: 60000 nM
Compound 4: the middle estimate sits 1.7-fold (0.22 log units) above what was measured; measured number inside the range.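

In this assay, the step is a 1.0-fold lower number from compound 3 to compound 4 (0.01 log units; within the scatter), which is within the scatter, so chloro on this aromatic carbon, ortho to a group of 7 heavy atoms, gives a value that cannot be told apart from that of the unsubstituted ring; the earlier compounds had shown only substituted rings ending in limits, and compound 4 goes against any reading that a ring substituent as such pushes the value to a limit. Compound 1, which carries methyl on this same carbon, gives a limit of > 100000 nM. The exchange of methyl for chloro reads as an at least 1.6-fold lower number from compound 1 to compound 4 (0.22 log units; that floor lies within the scatter), so it shows no real separation between the two groups, and only a floor can be stated: the limit of > 100000 nM in this assay, at which 2 of the 4 values shown sit.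

The compounds shown leave open whether bromo, methoxy or trifluoromethyl on this carbon, or an amine or a carboxylic acid, would give a number like chloro or a limit like methyl. They also leave open whether chloro gives a comparable value on the other carbons of the ring, and whether any group on the ring can bring the value beyond the scatter from that of compound 3.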